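Swapping phenoxy for iodo on a chloroacetyl urea

The compounds below may be only part of what the source reports. "The series", "measured", "known", "first", "only" and "open" are said of these compounds alone.

- compound 1 (`O=C(CCl)NC(=O)Nc1ccc(OC2CCCCC2)cc1`): 3100 nM
- compound 2 (`O=C(CCl)NC(=O)Nc1ccc(Oc2ccccc2)cc1`): 3600 nM

For the measured compounds named here, in a functional assay on HT-29 cells (Homo sapiens) for inhibition, read by sulforhodamine B assay, with a stated time of 48 h (on this read-out lower numbers stand for stronger inhibition of growth and higher numbers for weaker inhibition of growth), compound 2 gives 3600 nM and stands within the usual scatter of compound 1, the only other measured compound. The next compound, compound 3 (`O=C(CCl)NC(=O)Nc1ccc(I)cc1`), differs from compound 2 in one place: iodo in place of phenoxy on an aromatic carbon. In words, this is iodo in place of phenoxy on an aromatic carbon.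

Going by the values given here, only one measured step bears on this change, and it is small: a 1.2-fold higher number from compound 1 to compound 2 (0.06 log units; within the scatter), which lies within the scatter. That step replaced phenyl with cyclohexyl in reverse, keeping the oxygen and a six-membered ring on it. Iodo keeps neither, so the step is only a weak guide. Among the compounds with values here, no measured compound carries iodo, and the data point in neither direction. No shift beyond the scatter is therefore expected, although the uncertainty is wide. The estimated change is a 1.1-fold higher number from compound 2 to compound 3 (0.05 log units; within the scatter) and stays within the scatter. For compound 3 the estimated value is 4000 nM, with an expected range from 1500 nM to 11000 nM in this assay.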

Compound 3, concentration for 50% growth inhibition: 6900 nM
Estimate against measurement, compound 3: 1.7-fold (0.24 log units) below; the measured number falls inside the stated range.
By their numbers in this assay, from the lowest: compounds 1, 2 and 3 (each within the scatter of the next, the first and the last beyond it).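

Removing the phenoxy group, with its 7 heavy atoms, its oxygen and its aromatic ring, and leaving a single iodine atom on that aromatic carbon gives a 1.9-fold higher number from compound 2 to compound 3 (0.28 log units; within the scatter) in this assay. So, measured against compound 2, neither the oxygen nor the second ring is shown to be needed for growth inhibition at this level, which the earlier pair could not show because both of its members kept that oxygen and a six-membered ring. For the compounds shown here, the comparison with the cyclohexyloxy compound reads differently, with a 2.2-fold higher number from compound 1 to compound 3 (0.35 log units; beyond the scatter), a modest loss and the first step in this set to pass the scatter, so this position does respond to its substituent, though only slightly; nothing available here gives a reason for that response.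

Still open, as far as these compounds go, is how this position would respond to groups of quite another kind, such as an amine, a carboxylic acid or a longer chain like butoxy. Also open is whether the small differences among these three compounds would hold with the chloroacetyl urea part of the core changed, for example with bromoacetyl in place of chloroacetyl.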